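The source may hold more compounds than are shown below. What is called first, only, known or untested is meant among the compounds shown, and "the series" means these compounds.

Measured compounds: compound 1 `COc1cc(-c2cc(/C=C/C(=O)c3ccc(N)cc3)[nH]n2)cc(OC)c1OC`, 8420 nM; compound 2 `COc1ccc(-c2cc(/C=C/C(=O)c3ccc(N)cc3)[nH]n2)cc1OC`, 7800 nM; compound 3 `COc1ccc(-c2cc(/C=C/C(=O)c3cc(OC)c(OC)c(OC)c3)[nH]n2)cc1OC`, 8030 nM.

In a functional assay on MDA-MB-468 cells (Homo sapiens) for inhibition, read by sulforhodamine B assay, with a stated time of 48 h (on this read-out lower numbers stand for higher toxicity in this test and higher numbers for lower toxicity in this test), compound 1 gives the highest of the three numbers, yet all three lie within the usual scatter of one another. Compound 4 `COc1ccc(C(=O)/C=C/c2cc(-c3cc(OC)c(OC)c(OC)c3)n[nH]2)cc1` differs from compound 1 by methoxy in place of amino on an aromatic carbon. Going by the values given here, no measured step touches this exact change; the only single-point step, a 1.1-fold lower number from compound 1 to compound 2 (0.03 log units; within the scatter), concerns a different part of the molecule and stays within the scatter, and the values of compound 1 and compound 3, which differ at the ketone-side ring, likewise sit close together. He therefore expects no change beyond the scatter, with a step of a 1.1-fold lower number from compound 1 to compound 4 (0.02 log units; within the scatter). For compound 4 the estimated value is 8000 nM, within a range of 4000 nM to 16000 nM.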

Compound 4, concentration lethal to 50% of the cells: 5450 nM
Compound 4: middle estimate off by 1.5-fold (0.17 log units), on the high side; measured number inside the range.
By their numbers in this assay, from the lowest: compounds 4, 2, 3 and 1 (each within the scatter of the next).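

In this assay the 4-aminophenyl to 4-methoxyphenyl change gives a 1.5-fold lower number from compound 1 to compound 4 (0.19 log units; within the scatter) and so stays within the scatter. This gives the position on this ring its first direct step: the amino group, with its hydrogen-bond donor, can give way to methoxy without the number moving beyond the scatter. No evidence available here bears on the reason for this result.

The compounds shown leave open whether a carboxylic acid or a dimethylamino group at this place would move the number beyond the scatter. They also leave open whether a hydroxyl group would do so.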